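Hydrazone series: phenol methylation and cytotoxicity on lung cells

The compounds below may be only part of what the source reports. "The series", "measured", "known", "first", "only" and "open" are said of these compounds alone.

Compound 1 `Cn1nnnc1SCC(=O)N/N=C/c1ccc(O)cc1` and compound 3 `Cn1nnnc1SCC(=O)N/N=C/c1cccc(O)c1` share the same atoms joined differently; how the two cores differ is not broken down here. In a functional assay on A549 cells (Homo sapiens) for cytotoxicity, read by XTT assay, with a stated time of 24 h (on this read-out higher numbers stand for weaker inhibition and lower numbers for stronger inhibition), compound 1 gives only a limit of > 10000000 nM. Compound 2 `COc1ccc(/C=N/NC(=O)CSc2nnnn2C)cc1`, carrying (methyl in place of hydrogen on an oxygen on an aromatic ring), also gives only a limit in this assay, namely > 10000000 nM. The step that the two limits leave unreadable from compound 1 to compound 2 cannot be sized because both ends sit at the limit of > 10000000 nM in this assay, at which 2 of the 3 values shown sit. Within the data shown here, compound 3 gives 4500000 nM in this assay, the only number in the set. Compound 4 `COc1cccc(/C=N/NC(=O)CSc2nnnn2C)c1` carries the same change against compound 3, (methyl in place of hydrogen on an oxygen on an aromatic ring). With the earlier step unreadable, the expectation rests only on compound 3 at 4500000 nM. Compound 1 and compound 2 add no readable size to it. The estimated step of a 1.8-fold higher number from compound 3 to compound 4 (0.25 log units; within the scatter) is expected to run toward weaker inhibition. Compound 4 is expected to give about 8000000 nM, between 2500000 nM and 30000000 nM, with a fair chance of a limit only.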

Compound 4, half-maximal inhibitory concentration: > 10000000 nM
Compound 4 gave a limit, no number; the forecaster's own chance of this, stated with the estimate: 50%; at least 1.2-fold (0.09 log units) between middle value and limit.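

On the core of compound 3, hydroxy to methoxy gives in this assay an at least 2.2-fold higher number from compound 3 to compound 4 (0.34 log units; beyond the scatter), a step toward weaker inhibition whose full size may be larger. Compound 4 gives only a limit, > 10000000 nM. The same change from compound 1 to compound 2 cannot be read, so carry-over of the step from one core to the other is not shown, and most of the series sits at one limit: the limit of > 10000000 nM in this assay, at which 3 of the 4 values shown sit.

Open, as far as these compounds go, is whether an amine or a carboxylic acid in place of the hydroxy group would give a readable number on either core. Also open, from the compounds shown here alone, is how a longer chain in place of the methyl on the oxygen would read on the core of compound 3.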